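Trimming the acyl urea of compound 3 to a plain ureido

This account rests on a few compounds, and the source may have more. Where it says the series, first, only, none or still open, it means among the compounds named here.

Three measured compounds share one core. In a functional assay on HEL cells (Homo sapiens) for cytotoxicity, read by microscopy (on this read-out lower numbers stand for higher toxicity in this test and higher numbers for lower toxicity in this test), compound 1 `Cc1cn([C@@H]2O[C@H](CO[Si](C)(C)C(C)(C)C)[C@@]3(OS(=O)(=O)C=C3NCC(=O)O)[C@H]2O[Si](C)(C)C(C)(C)C)c(=O)n(C)c1=O` gives 300000 nM, compound 2 `Cc1cn([C@@H]2O[C@H](CO[Si](C)(C)C(C)(C)C)[C@@]3(OS(=O)(=O)C=C3NCC(N)=O)[C@H]2O[Si](C)(C)C(C)(C)C)c(=O)n(C)c1=O` gives 16000 nM, and compound 3 `C=C(C)C(=O)NC(=O)NC1=CS(=O)(=O)O[C@@]12[C@@H](CO[Si](C)(C)C(C)(C)C)O[C@@H](n1cc(C)c(=O)n(C)c1=O)[C@@H]2O[Si](C)(C)C(C)(C)C` gives 20000 nM. Compound 3 therefore holds the second highest of the three numbers: its value sits within the scatter of compound 2, as a 1.3-fold higher number from compound 2 to compound 3 (0.10 log units; within the scatter) shows, while a 15-fold lower number from compound 1 to compound 3 (1.18 log units; beyond the scatter) separates it clearly from compound 1. Compound 4 `Cc1cn([C@@H]2O[C@H](CO[Si](C)(C)C(C)(C)C)[C@@]3(OS(=O)(=O)C=C3NC(N)=O)[C@H]2O[Si](C)(C)C(C)(C)C)c(=O)n(C)c1=O` differs from compound 3 by hydrogen in place of (1-methylethenyl)carbonyl on an amide-type nitrogen. Going by the values given here, no measured step removes an acyl group from an amide-type nitrogen; the large steps of a 19-fold lower number from compound 1 to compound 2 (1.27 log units; beyond the scatter) and a 15-fold lower number from compound 1 to compound 3 (1.18 log units; beyond the scatter) concern the acid of compound 1, and the step from compound 2 to compound 3, though changing the nitrogen substituent, stays within the scatter. For compound 4 this writer therefore expects no change at the digits printed from compound 3 to compound 4 (within the scatter), no step beyond the scatter, and estimates 20000 nM, between 5000 nM and 80000 nM.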

Compound 4, minimum cytotoxic concentration: 16000 nM
Compound 4: the middle estimate sits 1.3-fold (0.10 log units) above what was measured, and the stated range covers the measured number.
By their numbers in this assay, from the lowest: compounds 2, 4 and 3 (each within the scatter of the next); then compound 1.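

In this assay, taking (1-methylethenyl)carbonyl off the amide-type nitrogen leaves the number within the scatter (a 1.3-fold lower number from compound 3 to compound 4 (0.10 log units; within the scatter)), so the plain ureido reads like the acyl urea. Carbamoyl in place of carbamoylmethyl on the amine nitrogen also shows (no change at the digits printed from compound 2 to compound 4 (within the scatter)), whereas compound 1, with its carboxymethyl, stays clearly apart (a 19-fold lower number from compound 1 to compound 4 (1.27 log units; beyond the scatter)). Among these four compounds, only the one carrying the carboxylic acid stands apart. On these data alone, how a benzoyl group or a longer acyl chain on that nitrogen would read remains open. Nothing shown here explains these numbers.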